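The compounds below may be only part of what the source reports. "The series", "measured", "known", "first", "only" and "open" are said of these compounds alone.

Series in a functional assay on KB cells (Homo sapiens) for antiproliferative activity, read by sulforhodamine B assay, with a stated time of 3 days; on this read-out higher numbers stand for an effect only at larger amounts of compound and lower numbers for an effect already at smaller amounts:
- compound 1 `CCC1=C(O)c2c(oc(-c3ccccc3)cc2=O)C(CC)(CC)C1=O`: > 236 uM (a limit of the assay, not a number)
- compound 2 `CCC1=C(O)c2c(oc(-c3ccc(C)cc3)cc2=O)C(CC)(CC)C1=O`: 39.2 uM
- compound 3 `CCC1=C(O)c2c(oc(-c3ccc(F)cc3)cc2=O)C(CC)(CC)C1=O`: 33 uM
- compound 4 `CCC1=C(O)c2c(oc(-c3ccc(COC)cc3)cc2=O)C(CC)(CC)C1=O`: not yet measured

For the measured compounds named here, compound 3 is not separated from its only numeric neighbour: a 1.2-fold lower number from compound 2 to compound 3 (0.07 log units; within the scatter). Both of these numbers stand clear of the limit, as an at least 7.1-fold lower number from compound 1 to compound 3 (0.85 log units; beyond the scatter) and an at least 6.0-fold lower number from compound 1 to compound 2 (0.77 log units; beyond the scatter) show.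

The next step places methoxymethyl in place of fluoro on an aromatic carbon, para to a large group: methoxymethyl in place of fluoro on an aromatic carbon.

Going by the values given here, three measured steps bear on this change, all on that same aromatic carbon. Replacing hydrogen gave an at least 6.0-fold lower number from compound 1 to compound 2 (0.77 log units; beyond the scatter) and an at least 7.1-fold lower number from compound 1 to compound 3 (0.85 log units; beyond the scatter), each measured from a limit. Among the compounds with values here, exchanging one substituent for another gave a 1.2-fold lower number from compound 2 to compound 3 (0.07 log units; within the scatter), and this is the closest precedent. No shift beyond the scatter is therefore expected in this assay, and no direction is favoured.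

The estimated step is a 1.1-fold higher number from compound 3 to compound 4 (0.03 log units; within the scatter).

The expected value for compound 4 is 35 uM, with an estimated range from 12 uM to 110 uM.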

Compound 4, concentration for half-maximal effect: > 52.4 uM
Compound 4: a limit, no number; the forecaster's own chance of this, stated with the estimate: 15%; middle value at least 1.4-fold (0.17 log units) away from the limit.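

In this assay compound 4 gives no number, only a limit: the limit of > 52.4 uM in this assay, at which 1 of the 4 values shown sits. Methoxymethyl is the first group on this aromatic carbon to carry a hydrogen-bond acceptor, and the readable steps are an at least 1.5-fold higher number from compound 3 to compound 4 (0.20 log units; that floor lies within the scatter) and an at least 1.3-fold higher number from compound 2 to compound 4 (0.12 log units; that floor lies within the scatter); both are floors, so methoxymethyl is neither separated from fluoro and methyl nor shown to match them. The step from compound 1 to compound 4 cannot be read, which leaves the gain seen on replacing hydrogen with methyl or fluoro unconfirmed for methoxymethyl.

Open, as far as these compounds go, is whether compound 4 has a true value close to those of compound 2 and compound 3 or far from them. Also open, from the compounds shown here alone, is how an aminomethyl group, a carboxylic acid or a longer ether chain on this carbon would read out.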